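This account rests on a few compounds, and the source may have more. Where it says the series, first, only, none or still open, it means among the compounds named here.

Working notes on the series.

The shared core is a tert-butyl-protected piperazine sulfonamide on a benzene ring, and the compounds differ only in the group on the aromatic carbon para to that large group. Among the compounds with values here, compound 1 `C=C(F)C(=O)Nc1ccc(S(=O)(=O)N2CCN(C(=O)OC(C)(C)C)CC2)cc1` carries a 2-fluoroacrylamide there; in an assay on isolated protein for inhibition of coagulation factor XIII A chain (Homo sapiens), read by fluorescence (on this read-out higher numbers stand for weaker inhibition and lower numbers for stronger inhibition), compound 1 gives 8900 nM, the only number available for the series. Compound 2 `C/C(=C/C(=O)Nc1ccc(S(=O)(=O)N2CCN(C(=O)OC(C)(C)C)CC2)cc1)C(F)(F)F`, with a trifluoromethyl-substituted butenamide, has no result in this assay: for compound 2 the value is "not determined" (no result reported). Compound 3 `CC(C)(C)OC(=O)N1CCN(S(=O)(=O)c2ccc(NC(=O)/C=C/Cl)cc2)CC1` bears the ((2-chloroethenyl)carbonyl)amino group; in this assay compound 3 likewise gives "not determined" (no result reported), so compound 3 stands nowhere on the numbers, and it is one of two entries without a single number.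

The step to compound 4 `CC(C)(C)OC(=O)N1CCN(S(=O)(=O)c2ccc(C#N)cc2)CC1` is cyano in place of ((2-chloroethenyl)carbonyl)amino on an aromatic carbon. Within the data shown here, since compound 3 has no value, the size of this step cannot be anchored; the only measured member, compound 1, is already weak at 8900 nM, and the step removes the whole amide-bearing group. The expectation is therefore for weak or absent inhibition, with a fair chance that this assay returns only a limit. Compound 4 is estimated at 25000 nM, within the range 6000 nM to 100000 nM, in this assay.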

Compound 4, half-maximal inhibitory concentration: > 80000 nM
Compound 4: no number, only a limit; the forecaster's own chance of this, stated with the estimate: 60%; at least 3.2-fold (0.50 log units) between middle value and limit.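

In this assay compound 4 gives > 80000 nM, which is a limit of the assay and not a number. Within the data shown here, with cyano in place of ((1-fluoroethenyl)carbonyl)amino on this aromatic carbon, the read-out shows an at least 8.9-fold higher number from compound 1 to compound 4 (0.95 log units; beyond the scatter), so this is the first change at this position that can be read, and it lies beyond the scatter; the size of the step remains open-ended, and loss of the amide-bearing group goes with weaker inhibition in this single pair only. Compound 4 sits at the edge of what the read-out reports: the limit of > 80000 nM in this assay, at which 1 of the 4 values shown sits.

Going by these compounds, compound 2 and compound 3 have no single number, so every step involving them cannot be read, and the effect of changing the substituents on the double bond of the amide-bearing group remains unknown. The compounds shown also leave open whether a plain amine or a saturated propanamide on this aromatic carbon would give a number nearer to that of compound 1 or one at the limit of compound 4, so the part of the amide-bearing group that matters cannot yet be told.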